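Replacing the Pyridin-4-yl Arm: Working Notes Toward Compound 3

The source may hold more compounds than are shown below. What is called first, only, known or untested is meant among the compounds shown, and "the series" means these compounds.

Among the compounds with values here, compound 2 `CNc1nc(NCc2ccncc2)cc(-c2ccccn2)n1` stands lowest of the two numbers so far in a functional assay on HEK293 cells for agonist activity at G-protein coupled receptor 39 (Mus musculus), read by inositol phosphate accumulation (a lower number here means that less compound is needed, a higher number that more compound is needed for the effect), giving 304 nM. Compound 1 `CNc1nc(NCc2ccc(N(C)C(C)=O)cc2)cc(-c2ccccn2)n1` gives 2610 nM in this assay, a higher number by a margin beyond the scatter. Compound 3 `CNc1nc(NCc2ccc(Cl)cc2Cl)cc(-c2ccccn2)n1` differs from compound 2 in one place: 2,4-dichlorophenyl in place of pyridin-4-yl on a saturated chain carbon bound to a nitrogen on an aromatic ring. Within the data shown here, no measured pair covers this change, so its size is open. A modest step toward a higher number, near the edge of the scatter, is expected: a 2.0-fold higher number from compound 2 to compound 3 (0.30 log units; within the scatter). In this assay compound 3 is estimated at 600 nM, with a range from 150 nM to 2500 nM.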

Compound 3, half-maximal effective concentration: 0.5 nM
Estimate against measurement, compound 3: 1200-fold (3.08 log units) above; the measured number lies below the stated range.
By their numbers in this assay, from the lowest: compound 3; then compound 2; then compound 1.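

In this assay, 2,4-dichlorophenyl in place of pyridin-4-yl on a saturated chain carbon bound to a nitrogen on an aromatic ring gives a 610-fold lower number from compound 2 to compound 3 (2.78 log units; beyond the scatter) and marks this arm as a strong determinant of the number. No available evidence bears on the origin of this step. The compounds shown leave open how much of the step belongs to the chlorines and how much to the loss of the ring nitrogen. Phenyl, 2-chlorophenyl and 4-chlorophenyl arms would separate these contributions.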